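Cytotoxicity of a Shared Core With Varied Para Groups

The source may hold more compounds than are shown below. What is called first, only, known or untested is meant among the compounds shown, and "the series" means these compounds.

Three compounds built on one shared core have been examined in an ADME assay on L929 cells (Mus musculus) for cytotoxicity, read by resazurin assay, with a stated time of 72 h; on this read-out higher numbers stand for weaker inhibition and lower numbers for stronger inhibition. Compound 1 `O=C(/C=C/c1ccc2c(c1)B(O)OC2)c1ccc(O)cc1` carries a hydroxy group on its terminal ring; in this assay compound 1 gives > 10 ug/mL, which is a limit of the assay and not a number. Compound 2 `O=C(/C=C/c1ccc2c(c1)B(O)OC2)c1ccc(OCc2ccccc2)cc1` carries a benzyloxy group instead; in this assay compound 2 gives > 10 ug/mL, likewise a limit. Compound 3 `Nc1ccc(C(=O)/C=C/c2ccc3c(c2)B(O)OC3)cc1` carries an amino group; in this assay compound 3 gives > 10 ug/mL, again a limit. Compound 3 therefore stands where the other two stand, at the limit of > 10 ug/mL in this assay, at which 3 of the 3 values shown sit. The steps a step that the two limits leave unreadable from compound 1 to compound 2, a step that the two limits leave unreadable from compound 1 to compound 3 and a step that the two limits leave unreadable from compound 2 to compound 3 all remain of unreadable size, since both ends of each sit at a limit.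

Compound 4 `CCOC(=O)c1ccc(C(=O)/C=C/c2ccc3c(c2)B(O)OC3)cc1` differs from compound 3 as follows: ethoxycarbonyl in place of amino on an aromatic carbon. For the measured compounds named here, no measured step bearing on this change has a readable size, so no step beyond the scatter can be expected in this assay in either direction, and compound 4 is most likely to sit at the limit as well. The expected step is a step that the limit leaves unreadable from compound 3 to compound 4. Compound 4 is expected to give 15 ug/mL in this assay, with a range from 5 ug/mL to 50 ug/mL.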

Compound 4, half-maximal inhibitory concentration: > 10 ug/mL
Compound 4: a limit, no number; the forecaster's own chance of this, stated with the estimate: 80%; the middle value is on the limit's open side.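

Compound 4 gives > 10 ug/mL in this assay as a limit and not a number. For the compounds shown here, no step linking compound 4 to compound 1, compound 2 or compound 3 can be read, since all four compounds sit at a limit: the limit of > 10 ug/mL in this assay, at which 4 of the 4 values shown sit. The compounds shown leave open whether any of these groups on the terminal ring gives a value that can be read as a number, and how these groups would then rank.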